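The source may report more compounds than this note shows. Statements on the series, on what has been measured and on what is new or still open speak of the compounds shown alone.

In a physicochemical assay for lipophilicity (on this read-out higher numbers stand for higher lipophilicity and lower numbers for lower lipophilicity), compound 1 `N[C@H]1CC[C@H](Nc2ccc3ncc(-c4cnc(Nc5ncc(C(F)(F)F)cc5F)nc4)n3n2)CC1` gives 1.6 and compound 2 `Fc1cccnc1Nc1ncc(-c2cnc3ccc(N4CCNCC4)nn23)cn1` gives 0.7. Compound 2 is therefore the lower of the two, by a gap beyond the scatter. Compound 3 `CN1CCN(CCNc2ccc3ncc(-c4cnc(Nc5ncccc5F)nc4)n3n2)CC1` differs from compound 2 in one place: (2-(4-methylpiperazin-1-yl)ethyl)amino stands in place of piperazin-1-yl on an aromatic carbon ((2-(4-methylpiperazin-1-yl)ethyl)amino in place of piperazin-1-yl on an aromatic carbon). Among the compounds with values here, no measured pair shows this change, so the expectation is a loose one. An upward step in this assay, beyond the scatter, is expected, estimated as a number 0.70 log units higher from compound 2 to compound 3 (beyond the scatter). Compound 3 is expected at 1.4, with an estimated range of 0.8 to 2.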

Compound 3, distribution coefficient: 1.6
For compound 3 the middle estimate is 0.20 log units below the measured one; the measured number falls inside the stated range.
By their numbers in this assay, from the lowest: compound 2; then compounds 1 and 3 (each within the scatter of the next).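

Within the data shown here, at this aromatic carbon, setting (2-(4-methylpiperazin-1-yl)ethyl)amino in place of piperazin-1-yl gives, in this assay, a number 0.90 log units higher from compound 2 to compound 3 (beyond the scatter), the first step that can be read at this position. The entering group keeps the six-membered non-aromatic ring but adds heavy atoms and a hydrogen-bond acceptor. No supporting evidence bears on this step.

Among these compounds, the single step does not separate the contributions of the ethyl chain, the amino link and the methyl on the piperazine. On these data alone, how a morpholine or a shorter chain at this carbon would read also remains open.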